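Fluoro for cyclopropylcarbonyl: compound 1 to compound 4

The compounds below may be only part of what the source reports. "The series", "measured", "known", "first", "only" and "open" are said of these compounds alone.

Measured in an in vitro ADME assay on microsomes from liver (Homo sapiens) for metabolic stability; on this read-out lower numbers stand for a shorter-lived compound and higher numbers for a longer-lived compound:
- compound 1 `O=C(c1ccc2c(c1)CC(c1nc3ccc(-c4cn[nH]c4)cc3c(=O)[nH]1)CO2)C1CC1` gives 3.63 h
- compound 2 `O=c1[nH]c(C2=Cc3ccccc3OC2)nc2ccc(-c3cn[nH]c3)cc12` gives 7.3 h
- compound 3 `O=c1[nH]c(C2CCc3ccccc3O2)nc2ccc(-c3cn[nH]c3)cc12` gives 1.03 h

Compound 1 cannot be separated from compound 2 on these numbers, as their two values lie within the scatter of each other. Compound 3 lies beyond the scatter below compound 1, so compound 1 sits with the upper pair of this small set.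

Not yet measured is compound 4 `O=c1[nH]c(C2COc3ccc(F)cc3C2)nc2ccc(-c3cn[nH]c3)cc12`. The change from compound 1 is fluoro in place of cyclopropylcarbonyl on an aromatic carbon. Put simply, cyclopropylcarbonyl goes and fluoro takes its spot, which lies on a six-membered aromatic ring of carbon only, part of a fused or bridged system of two rings.

Going by the values given here, no pair of measured compounds differs in one place only, and no measured compound carries fluoro, so the data offer no direct read on this change. In this assay no step beyond the scatter is therefore expected, and any direction is only weakly favoured. The expected change is a 1.1-fold higher number from compound 1 to compound 4 (0.04 log units; within the scatter). The range stays wide, close to the span of the three measured values. For compound 4 the estimated half-life is 4 h, with an expected range of 1.5 h to 10 h.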

Compound 4, half-life: 2.38 h
The estimate for compound 4 lay 1.7-fold (0.23 log units) above the measured number; measured number inside the range.
By their numbers in this assay, from the lowest: compound 3; then compounds 4, 1 and 2 (each within the scatter of the next, the first and the last beyond it).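

Replacing cyclopropylcarbonyl with fluoro on this aromatic carbon gives, in this assay, a 1.5-fold lower number from compound 1 to compound 4 (0.18 log units; within the scatter), so the two compounds cannot be told apart on this read-out. Going by these compounds alone, this is the first direct read at this position: a group of 5 heavy atoms with a three-membered ring and a hydrogen-bond acceptor gives way to a single fluorine, and no step beyond the scatter follows. Nothing at hand gives a cause for this result.

Within the data shown here, this single pair shows only that these two groups are not separated here, and compound 2 and compound 3 differ from compound 1 in more than one place, so they add nothing about this position. As far as these compounds go, how an amine, a carboxylic acid or a longer chain on the same aromatic carbon would read in this assay remains open, as does whether any group there can produce a step beyond the scatter.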